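This account rests on a few compounds, and the source may have more. Where it says the series, first, only, none or still open, it means among the compounds named here.

Measured so far in a functional assay on HCT-116 cells (Homo sapiens) for antiproliferative activity; on this read-out lower numbers stand for stronger inhibition and higher numbers for weaker inhibition:
- compound 1 `Cc1c2c(n3c1CCNC[C@@H](C)[C@H](C)Nc1cc-3ccc1C(N)=O)CC(C)(C)CC2=O`: 24 nM
- compound 2 `Cc1c2c(n3c1CCN(C(=O)C1(N)CC1)C[C@@H](C)[C@H](C)Nc1cc-3ccc1C(N)=O)CC(C)(C)CC2=O`: 81 nM

Of these two, compound 2 has the higher number, so it is the weaker inhibitor. Within the data shown here, the next molecule, compound 3 `Cc1c2c(n3c1CCN(C(=O)[C@H](C)O)C[C@@H](C)[C@H](C)Nc1cc-3ccc1C(N)=O)CC(C)(C)CC2=O`, keeps the core of compound 2 and alters only one group: 1-hydroxyethyl in place of 1-aminocyclopropyl on a carbonyl carbon. In words, 1-hydroxyethyl stands in place of 1-aminocyclopropyl on a carbonyl carbon.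

Among the measured compounds shown here, only one measured step bears on this. It is a 3.4-fold higher number from compound 1 to compound 2 (0.53 log units; beyond the scatter), with (1-aminocyclopropyl)carbonyl in place of hydrogen on an amine nitrogen in a ring. No direct swap of one such group for another has been measured. Adding the whole group to compound 1 gave only a modest step, a 3.4-fold higher number from compound 1 to compound 2 (0.53 log units; beyond the scatter), so a swap within that group is expected to move the number no further. The expected step, a 1.2-fold lower number from compound 2 to compound 3 (0.10 log units; within the scatter), is small. Compound 3 is estimated at 65 nM, with an expected range of 28 nM to 150 nM.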

Compound 3, half-maximal inhibitory concentration: 42 nM
Beside the measured number, compound 3's estimate is 1.5-fold (0.19 log units) above it; the measured number falls inside the stated range.
By their numbers in this assay, from the lowest: compounds 1, 3 and 2 (each within the scatter of the next, the first and the last beyond it).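

In this assay, the swap on this carbonyl carbon gives (a 1.9-fold lower number from compound 2 to compound 3 (0.29 log units; within the scatter)), so 1-hydroxyethyl, which has no ring and no nitrogen, cannot be told apart from 1-aminocyclopropyl here. Placing (1-hydroxyethyl)carbonyl on the amine nitrogen in the ring gives (a 1.8-fold higher number from compound 1 to compound 3 (0.24 log units; within the scatter)), so compound 3 also cannot be told apart from compound 1, although the step from compound 1 to compound 2 lies beyond the scatter. Nothing shown gives a reason for these numbers.

From the compounds shown here alone, it remains open how the mirror-image arrangement at the stereocentre of 1-hydroxyethyl would read in this assay. A longer chain, a carboxylic acid or a simple aminomethyl group on this carbonyl carbon would show how much change the position tolerates.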